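A Second Chloro: From 2-Chlorophenyl to 2,6-Dichlorophenyl

A few compounds are considered here, and "the series" means these few. Any claim that something is new, unique, unknown or untested is made for them only; others in the source may bear on it.

Compound 1 `O=C(NO)c1ccc(CNC(=O)c2n[nH]cc2NC(=O)c2ccccc2Cl)cc1` gives 2400 nM in a functional assay on HCT-116 cells (Homo sapiens) for inhibition, read by CCK-8 assay, with a stated time of 72 h; on this read-out higher numbers stand for weaker inhibition and lower numbers for stronger inhibition.
Compound 2 `Nc1ccccc1NC(=O)c1ccc(CNC(=O)c2n[nH]cc2NC(=O)c2ccccc2)cc1` gives 1660 nM in this assay.
Compound 3 `Nc1ccccc1NC(=O)c1ccc(CNC(=O)c2n[nH]cc2NC(=O)c2ccccc2Cl)cc1` gives 900 nM in this assay.

Among these three numbers compound 1 has the highest, with compound 2 within the scatter of it, while the gap to compound 3 is a 2.7-fold lower number from compound 1 to compound 3 (0.43 log units; beyond the scatter). Compound 4 `O=C(NO)c1ccc(CNC(=O)c2n[nH]cc2NC(=O)c2c(Cl)cccc2Cl)cc1` differs from compound 1 by chloro in place of hydrogen on an aromatic carbon. Among the measured compounds shown here, the only measured step of the same kind is a 1.8-fold lower number from compound 2 to compound 3 (0.27 log units; within the scatter), which did not reach beyond the scatter. Compound 4 is therefore expected to come out close to compound 1, perhaps a little lower, and its number in this assay is estimated at 1800 nM, between 700 nM and 4500 nM. This expectation means a 1.3-fold lower number from compound 1 to compound 4 (0.12 log units; within the scatter).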

Compound 4, half-maximal inhibitory concentration: 500 nM
The estimate for compound 4 lay 3.6-fold (0.56 log units) above the measured number; measured number below the stated range.
By their numbers in this assay, from the lowest: compounds 4, 3, 2 and 1 (each within the scatter of the next, the first and the last beyond it).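

In this assay, the change from 2-chlorophenyl to 2,6-dichlorophenyl gives a 4.8-fold lower number from compound 1 to compound 4 (0.68 log units; beyond the scatter), so chloro in place of hydrogen on this ring now produces a step beyond the scatter, which the earlier compounds had not shown. The larger step does not set the two cores apart, since the gap between the two steps stays within the scatter: the same change on two cores in this assay, a 1.8-fold lower number (0.27 log units; within the scatter) from compound 2 to compound 3 and a 4.8-fold lower number (0.68 log units; beyond the scatter) from compound 1 to compound 4, 2.6-fold (0.42 log units) apart, within the scatter of two such steps

The compounds shown leave open how 2,6-dichlorophenyl behaves on the core of compound 3. They also leave open whether a methoxy group or an amine in place of the second chloro would give a similar number.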